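The compounds below may be only part of what the source reports. "The series", "measured", "known", "first", "only" and "open" are said of these compounds alone.

Measured in an ADME assay on liver (Rattus norvegicus) for metabolic stability, read by LC-MS, using microsomes and NADPH, with a stated time of 40 min, tested at 1 uM; a higher number here means faster removal of the compound, a lower number slower removal:
- Compound 1 `COc1cc(C(F)(F)F)ccc1-c1cccc2cc(S(=O)(=O)Nc3ncns3)ccc12`: 18 mL.min-1.g-1
- Compound 2 `COc1cc(C(F)(F)F)ccc1-c1cccc2cc(S(=O)(=O)Nc3ccncn3)ccc12`: < 14 mL.min-1.g-1, a limit of the assay and not a number
- Compound 3 `COc1cc(C(F)(F)F)ccc1-c1cccc2cc(S(=O)(=O)Nc3ccccn3)ccc12`: 25 mL.min-1.g-1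

Compound 3 gives 25 mL.min-1.g-1, but it is not set apart from the other measured number: the step is a 1.4-fold higher number from compound 1 to compound 3 (0.14 log units; within the scatter). Compound 4 `COc1cc(C(F)(F)F)ccc1-c1cccc2cc(S(=O)(=O)Nc3ncccn3)ccc12` carries pyrimidin-2-yl in place of pyridin-2-yl on a sulfonamide nitrogen.

Going by the values given here, the closest precedent is the exchange of pyrimidin-4-yl for pyridin-2-yl, an at least 1.7-fold higher number from compound 2 to compound 3 (0.25 log units; that floor lies within the scatter). The remaining exchange on that nitrogen is an at least 1.2-fold lower number from compound 1 to compound 2 (0.10 log units; that floor lies within the scatter). Both of these steps rest on (the limit of < 14 mL.min-1.g-1 in this assay, at which 1 of the 3 values shown sits), so their true sizes are open. No measured step on this nitrogen is shown beyond the scatter, so no change beyond the scatter is expected in this assay, though a slight drift to a lower number would fit the direction seen with compound 2 and its < 14 mL.min-1.g-1.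

The expected step is a 1.4-fold lower number from compound 3 to compound 4 (0.14 log units; within the scatter). Compound 4 is estimated at 18 mL.min-1.g-1, with an expected range of 10 mL.min-1.g-1 to 32 mL.min-1.g-1.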

Compound 4, intrinsic clearance in microsomes: < 14 mL.min-1.g-1
Compound 4: a limit, no number (the forecaster's own chance of this, stated with the estimate: 30%); at least 1.2-fold (0.10 log units) between middle value and limit.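

In this assay compound 4 gives < 14 mL.min-1.g-1, which is a limit of the assay and not a number. Compound 4 thereby joins compound 2, so pyrimidin-2-yl and pyrimidin-4-yl both stand at that limit and the step between these two compounds cannot be read: the limit of < 14 mL.min-1.g-1 in this assay, at which 2 of the 4 values shown sit. Against pyridin-2-yl the exchange gives an at least 1.7-fold lower number from compound 3 to compound 4 (0.25 log units; that floor lies within the scatter), and against 1,2,4-thiadiazol-5-yl it gives an at least 1.2-fold lower number from compound 1 to compound 4 (0.10 log units; that floor lies within the scatter); both floors lie within the scatter, though the true sizes may be larger.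

From the compounds shown here alone, how far the true values of compound 2 and compound 4 lie under the limit stays open, and so does whether any exchange on this nitrogen goes beyond the scatter. Also open, going by these compounds, is what an amino-substituted pyrimidin-2-yl or a thiazol-2-yl on that nitrogen would give in this assay.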